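Swapping the Aryl Group of Compound 2

The source may hold more compounds than are shown below. What is called first, only, known or untested is meant among the compounds shown, and "the series" means these compounds.

Of the compounds shown here, three of a shared core have so far been tested in a functional assay on NCI-H2122 cells (Homo sapiens) for inhibition, read by microscopy, with a stated time of 10 days; a higher number here means a weaker inhibitor, a lower number a stronger inhibitor. Compound 1 `Cc1nn(C)c2c1C(c1ccccc1)C(C#N)=C(N)O2` gives 9100 nM, compound 2 `Cn1nc(-c2ccccc2)c2c1OC(N)=C(C#N)C2c1cc(F)cc(F)c1` gives 6600 nM, and compound 3 `Cc1nn(C)c2c1C(c1ccc(C(F)(F)F)cc1)C(C#N)=C(N)O2` gives 2200 nM. Compound 2 thus stands second highest of the three numbers: its value and that of compound 1 lie within the scatter of each other, while compound 3 sits a clear step lower.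

The new compound, compound 4 `Cn1nc(-c2ccccc2)c2c1OC(N)=C(C#N)C2c1ccc(C#N)cc1`, differs from compound 2 in one place: 4-cyanophenyl in place of 3,5-difluorophenyl on a saturated ring carbon. Within the data shown here, the only measured step that touches the same aryl group is the one from compound 1 to compound 3, a 4.1-fold lower number from compound 1 to compound 3 (0.62 log units; beyond the scatter), where a substituent entered the phenyl ring and the number fell by a modest amount. The present change is not the same, since one substituted phenyl is exchanged for another rather than a hydrogen being replaced, so that measured step can only loosely guide the expectation. A modest lowering of the number, or no change beyond the scatter, seems the most likely outcome in this assay.

Compound 4 is therefore expected to give 3300 nM in this assay, with a range from 1200 nM to 9000 nM. This estimate means an expected step of a 2.0-fold lower number from compound 2 to compound 4 (0.30 log units; within the scatter).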

Compound 4, half-maximal inhibitory concentration: 5200 nM
Compound 4: the middle estimate sits 1.6-fold (0.20 log units) below what was measured, and the stated range covers the measured number.
By their numbers in this assay, from the lowest: compound 3; then compounds 4, 2 and 1 (each within the scatter of the next).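

In this assay, exchanging 3,5-difluorophenyl for 4-cyanophenyl on the saturated ring carbon gives a 1.3-fold lower number from compound 2 to compound 4 (0.10 log units; within the scatter), so these two substituted aryl groups are not told apart on the core of compound 2. Among these compounds, the only earlier step at this aryl group, a 4.1-fold lower number from compound 1 to compound 3 (0.62 log units; beyond the scatter), replaced a hydrogen with trifluoromethyl on the core of compound 1 and lay beyond the scatter, whereas the present exchange shows that a substituted phenyl at this position can give way to a differently substituted one with the values remaining within the scatter of each other. It also shows that the hydrogen-bond acceptor counted on 4-cyanophenyl, absent from 3,5-difluorophenyl, comes with no readable difference in this cell assay, and no measurement at hand bears on the reason for this result.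

Going by these compounds, whether trifluoromethyl on the phenyl ring would give a step beyond the scatter on the core of compound 2, as it did on the core of compound 1, remains open. So does the question of whether an amine or a carboxylic acid on this aryl group would separate a compound from compound 2 and compound 4.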